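Urea series: cytotoxicity read-out, step to compound 4

This account rests on a few compounds, and the source may have more. Where it says the series, first, only, none or still open, it means among the compounds named here.

Measured so far in an ADME assay on BJ cells (Homo sapiens) for cytotoxicity, with a stated time of 72 h; on this read-out higher numbers stand for an effect only at larger amounts of compound and lower numbers for an effect already at smaller amounts:
compound 1 `Cc1cc(NC(=O)Nc2cccc(C(F)(F)F)c2)c2ccccc2n1` gives > 25000 nM, which is a limit of the assay.
compound 2 `Cc1cc(NC(=O)Nc2ccc(OC(F)(F)F)cc2)c2ccccc2n1` gives 25000 nM.
compound 3 `Cc1cc(NC(=O)Nc2ccc(C(F)(F)F)cc2)c2ccccc2n1` gives > 25000 nM, which is a limit of the assay.

Compound 1 stands at the limit of this assay, not at a number, and the limit of > 25000 nM in this assay, at which 2 of the 3 values shown sit, shows that two of the three values sit there. Compound 2 reports a number at the same concentration. Among the compounds with values here, the single measured step, a number no lower from compound 2 to compound 3 (the limit leaves the size open), runs from a number to a limit, so its size cannot be read.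

Compound 4 `Cc1cc(NC(=O)Nc2cccc(N(C)C)c2)c2ccccc2n1` differs from compound 1 by dimethylamino in place of trifluoromethyl on an aromatic carbon. Within the data shown here, no measured step bears on this change; all three measured values sit at or next to the limit, so nothing in this assay separates the compounds beyond the scatter. For compound 4 the expectation is that the read-out again stays at the limit, estimated at 25000 nM with a range from 10000 nM to 60000 nM. The step of a number no higher from compound 1 to compound 4 (the limit leaves the size open) is therefore expected to be none beyond the scatter.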

Compound 4, half-maximal effective concentration: > 25000 nM
Compound 4 gave a limit, no number; the forecaster's own chance of this, stated with the estimate: 65%; the middle value sits exactly at the limit.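

Within the data shown here, compound 1 and compound 4 each stand at a limit, not a number, in this assay, so no step between them can be read. The compounds shown leave open whether dimethylamino and trifluoromethyl differ at all on this read-out: the limit of > 25000 nM in this assay, at which 3 of the 4 values shown sit.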